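Moving the chlorine on the aryl ring of compound 1

This account rests on a few compounds, and the source may have more. Where it says the series, first, only, none or still open, it means among the compounds named here.

Compound 1 `S=C(Nc1ccccc1)N1N=C(c2ccc(Cl)cc2)CC1c1ccc2c(c1)OCCO2`: > 200000 nM
Compound 2 `Cc1ccc(C2=NN(C(=S)Nc3ccccc3)C(c3ccc4c(c3)OCCO4)C2)cc1`: > 200000 nM

In a functional assay on HCT-116 cells (Homo sapiens) for antiproliferative activity, read by MTT assay, with a stated time of 48 h (a lower number here means a stronger inhibitor of growth, a higher number a weaker inhibitor of growth), compound 1 gives > 200000 nM, which is a limit of the assay rather than a number. Compound 2 likewise returns > 200000 nM, again only a limit. The step that the two limits leave unreadable from compound 1 to compound 2 is therefore unreadable, since (the limit of > 200000 nM in this assay, at which 2 of the 2 values shown sit). Compound 3 `S=C(Nc1ccccc1)N1N=C(c2cccc(Cl)c2)CC1c1ccc2c(c1)OCCO2` differs from compound 1 by 3-chlorophenyl in place of 4-chlorophenyl on a carbon with a double bond to nitrogen. For the measured compounds named here, no measured step bears on this change in a readable way, so compound 1 offers only its limit as a guide. Compound 3 is expected to give 300000 nM (range 80000 nM to 1000000 nM), most likely again reported as a limit. The estimated step that the limit leaves unreadable from compound 1 to compound 3 is accordingly expected to be no more than the scatter.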

Compound 3, concentration for 50% growth inhibition: 138000 nM
Beside the measured number, compound 3's estimate is 2.2-fold (0.34 log units) above it; the range from low to high includes it.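

In this assay, for the compounds shown here, the 3-chlorophenyl group gives the only actual number at this position so far, where the 4-chlorophenyl and 4-methylphenyl groups gave only limits. The change to it is an at least 1.4-fold lower number from compound 1 to compound 3 (0.16 log units; that floor lies within the scatter), and the change from 4-methylphenyl is an at least 1.4-fold lower number from compound 2 to compound 3 (0.16 log units; that floor lies within the scatter). Only floors can be stated for these steps, so their true size stays unknown: the limit of > 200000 nM in this assay, at which 2 of the 3 values shown sit.

The compounds shown leave open whether a 3-methylphenyl or 3-aminophenyl group at this place would also give a number. They also leave open what a carboxylic acid on this ring would do.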